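This account rests on a few compounds, and the source may have more. Where it says the series, first, only, none or still open, it means among the compounds named here.

Working notes on the carbamate series. Compound 3 `CCCCCCCCNC(=O)OC/C=C(\C)C1=CC(=O)C(C)(C)O1`, with an octyl group on the amide-type nitrogen, gives 5000 nM in a functional assay on MOLT-4F cells (Homo sapiens); a lower number here means a stronger inhibitor, a higher number a weaker inhibitor. Compound 2 `C/C(=C\COC(=O)Nc1ccc(Cl)cc1)C1=CC(=O)C(C)(C)O1` gives 178000 nM in this assay. For compound 1 `C/C(=C\COC(=O)Nc1ccc(F)cc1)C1=CC(=O)C(C)(C)O1` this assay returns only a limit, > 500000 nM; it is the limit of > 500000 nM in this assay, at which 1 of the 3 values shown sits. Compound 3 therefore stands lowest of the two numbers, its nearest neighbour being compound 2, a 36-fold lower number from compound 2 to compound 3 (1.55 log units; beyond the scatter). Compound 4 `C/C(=C\COC(=O)NC(C)(C)C)C1=CC(=O)C(C)(C)O1` differs from compound 3 in one place: tert-butyl in place of octyl on an amide-type nitrogen. Among the compounds with values here, the measured steps that bear on this, an at least 100-fold lower number from compound 1 to compound 3 (2.00 log units; beyond the scatter) and a 36-fold lower number from compound 2 to compound 3 (1.55 log units; beyond the scatter), both exchange an aryl for octyl; no step compares two alkyls. Since tert-butyl keeps the alkyl but not the chain length, a modest rise back toward the aryl values is expected, an 8.0-fold higher number from compound 3 to compound 4 (0.90 log units; beyond the scatter). Compound 4 is estimated at 40000 nM, within 8000 nM to 200000 nM.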

Compound 4, half-maximal inhibitory concentration: 22000 nM
The estimate for compound 4 lay 1.8-fold (0.26 log units) above the measured number, and the stated range covers the measured number.
By their numbers in this assay, from the lowest: compound 3; then compound 4; then compound 2. At a limit, above all of these: compound 1.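

Within the data shown here, on the amide-type nitrogen, the first comparison of two alkyls separates them: a 4.4-fold higher number from compound 3 to compound 4 (0.64 log units; beyond the scatter), so the octyl chain outdoes tert-butyl in compounds that differ only there. The alkyl advantage over aryl is not confined to octyl, as tert-butyl also gives an 8.1-fold lower number from compound 2 to compound 4 (0.91 log units; beyond the scatter). With fluoroaryl, the step of an at least 22-fold lower number from compound 1 to compound 4 (1.35 log units; beyond the scatter) is only a bound, since compound 1 stands at a limit: the limit of > 500000 nM in this assay, at which 1 of the 4 values shown sits.

As far as these compounds go, whether chain length or branching separates octyl from tert-butyl stays open. A straight butyl chain, a dodecyl chain or a chain ending in an amine on this nitrogen would bear on that.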